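The source may report more compounds than this note shows. Statements on the series, on what has been measured and on what is new or still open speak of the compounds shown alone.

Measured in a functional assay on PC-3 cells (Homo sapiens) for cytotoxicity, read by MTT assay, with a stated time of 24 h; a lower number here means a stronger inhibitor, a higher number a weaker inhibitor:
Compound 1 `COc1ccc2c(c1)cc(-c1cc(OC)c(OC)c(OC)c1)n2Cc1ccc(O)cc1`: > 30000 nM, a limit
Compound 2 `COc1ccc(Cn2c(-c3cc(OC)c(OC)c(OC)c3)cc3cc(OC)ccc32)cc1`: > 30000 nM, a limit

Compound 2 has no exact number, only the limit > 30000 nM. The one other result, for compound 1, is also a limit, so the two compounds cannot be ranked.

Compound 3 `COc1ccc2c(c1)cc(-c1cc(OC)c(OC)c(OC)c1)n2Cc1ccc(OC(C)CN(C)C)cc1` keeps the shared core and differs from compound 2 in one place, with 1-((dimethylamino)methyl)ethyl in place of methyl on an oxygen on an aromatic ring.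

Among the compounds with values here, the only measured step that bears on this change also involves a group on such an oxygen: a step that the two limits leave unreadable from compound 1 to compound 2. The evidence so far is the limit of > 30000 nM in this assay, at which 2 of the 2 values shown sit. Within the data shown here, no measured step therefore gives a size to carry over, and any forecast is tentative. A modest move towards stronger inhibition is expected, though compound 3 may also stay at the limit. The expected change is an at least 3.0-fold lower number from compound 2 to compound 3 (0.47 log units; beyond the scatter). Compound 3 is estimated at 10000 nM, with an expected range from 2000 nM to 30000 nM.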

Compound 3, half-maximal inhibitory concentration: 13300 nM
Compound 3: middle estimate off by 1.3-fold (0.12 log units), on the low side; low and high end bracket the measured number.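

In this assay, within the data shown here, the oxygen on the aromatic ring is the first place in this set where a change gives a readable effect: 1-((dimethylamino)methyl)ethyl in place of methyl gives an at least 2.2-fold lower number from compound 2 to compound 3 (0.35 log units; beyond the scatter), and the same group in place of hydrogen gives an at least 2.2-fold lower number from compound 1 to compound 3 (0.35 log units; beyond the scatter). Compound 1 and compound 2 each stand at a limit, so these two steps give only a minimum size, and the step between those two compounds cannot be read. Compound 3 supplies the only exact number, while the rest of the set stays at the limit: the limit of > 30000 nM in this assay, at which 2 of the 3 values shown sit.

The compounds shown leave open whether the dimethylamino part or the carbon chain alone accounts for the lower number. A plain propyl group on the same oxygen, or a carboxylic acid in place of the dimethylamino part, would help to separate the two.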